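The source may hold more compounds than are shown below. What is called first, only, known or untested is meant among the compounds shown, and "the series" means these compounds.

Measured in a functional assay on OVCAR-3 cells (Homo sapiens) for cytotoxicity, read by sulforhodamine B assay; a lower number here means a stronger inhibitor of growth, a higher number a weaker inhibitor of growth:
Compound 1 `CC1=CC[C@@H]([C@@](C)(O)CCCC(C)(C)NC(=S)NN)CC1`: > 100000 nM
Compound 2 `CC1=CC[C@@H]([C@@](C)(O)CCCC(C)(C)NC(=S)N/N=C\c2ccccc2[N+](=O)[O-])CC1`: 16200 nM

The entry for compound 1 is a limit of the assay and not a number. For the measured compounds named here, compound 2, at 16200 nM, therefore holds the only actual number so far, and it is the sole reference point for what follows.

The next compound, compound 3 `CC1=CC[C@@H]([C@@](C)(O)CCCC(C)(C)NC(=S)N/N=C\c2cccc(Cl)c2)CC1`, carries 3-chlorophenyl in place of 2-nitrophenyl on a carbon with a double bond to nitrogen. The rest of the structure is shared with compound 2. Going by the values given here, no measured pair shows what a change at this place does, so no step beyond the scatter is expected in this assay, and neither direction is favoured with any confidence. The expected change is a 1.2-fold lower number from compound 2 to compound 3 (0.06 log units; within the scatter). The estimate for compound 3 is 14000 nM, within an expected range of 5000 nM to 40000 nM.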

Compound 3, concentration for total growth inhibition: 26500 nM
Compound 3: the middle estimate sits 1.9-fold (0.28 log units) below what was measured; low and high end bracket the measured number.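

The step of a 1.6-fold higher number from compound 2 to compound 3 (0.21 log units; within the scatter) shows that, in this assay, this place on a carbon with a double bond to nitrogen accepts 3-chlorophenyl as well as 2-nitrophenyl, even though the entering group has no hydrogen-bond acceptors and the leaving group does. The step of an at least 3.7-fold lower number from compound 1 to compound 3 (0.57 log units; beyond the scatter) gives a second case in which a compound with an aromatic ring at this end of the chain reaches a measured number. Compound 1 remains a limit of the assay and not a number, so the size of that second step stays open-ended: the limit of > 100000 nM in this assay, at which 1 of the 3 values shown sits.

As far as these compounds go, what a plain phenyl, or a ring carrying an amine or a carboxylic acid, would do at this place remains open. So does whether a methyl in place of the ring would keep a measurable number.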